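The source may hold more compounds than are shown below. What is called first, only, known or untested is meant among the compounds shown, and "the series" means these compounds.

Compound 1 `COc1ccc(C(=O)c2ccc3c(c2)C=CC(C)(C)O3)c(NC(=O)CBr)c1`: 2880 nM
Compound 2 `COc1ccc(C(=O)c2ccc(OC)c3c2C=CC(C)(C)O3)c(NC(=O)CO)c1`: 940 nM
Compound 3 `COc1ccc(C(=O)c2ccc(OC)c3c2OC(C)(C)C=C3)c(NC(=O)CN)c1`: 410 nM

All three values come from a functional assay on MCF7 cells (Homo sapiens) for antiproliferative activity, read by MTT assay, with a stated time of 48 h; a lower number here means a stronger inhibitor, a higher number a weaker inhibitor. Compound 1 has the highest number of the three, which makes it the weakest inhibitor here, and its gaps to both others lie beyond the scatter. Compound 4 `COc1ccc(C(=O)c2ccc3c(c2)C=CC(C)(C)O3)c(NC(=O)CN)c1` keeps the core of compound 1 and has amino in place of bromo on a saturated chain carbon bound to a carbonyl carbon. Among the measured compounds shown here, no measured pair shows this change alone. Compound 3 carries the same aminomethyl group on a different core and gives 410 nM, so a clear step to a lower number in this assay, beyond the scatter, is expected. The estimated change is a 3.6-fold lower number from compound 1 to compound 4 (0.56 log units; beyond the scatter). For compound 4 the estimate is 800 nM, with a range of 250 nM to 2500 nM.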

Compound 4, half-maximal inhibitory concentration: 680 nM
Compound 4: middle estimate off by 1.2-fold (0.07 log units), on the high side, within the range that was stated.
By their numbers in this assay, from the lowest: compounds 3, 4 and 2 (each within the scatter of the next, the first and the last beyond it); then compound 1.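

Within this assay the swap of bromo for amino on a saturated chain carbon bound to a carbonyl carbon, with the core unchanged, gives a 4.2-fold lower number from compound 1 to compound 4 (0.63 log units; beyond the scatter) and so ties a step to this one place. The earlier compounds shown here differed from each other in more than one place and could not show this. Nothing shown here explains why the amino group gives the lower number.

As far as these compounds go, whether a dimethylamino group or a longer chain such as aminoethyl would move the number further stays open. So does whether the same swap gives a similar step on the core of compound 3.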